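Compound 3 to compound 4: amino in place of methoxy

A few compounds are considered here, and "the series" means these few. Any claim that something is new, unique, unknown or untested is made for them only; others in the source may bear on it.

Measured in a functional assay on KB cells (nasopharynx, Homo sapiens) for antiproliferative activity; a lower number here means a stronger inhibitor, a higher number a weaker inhibitor:
compound 1 `Nc1ccc(S(=O)(=O)Nc2cccc3cc[nH]c23)cc1`: 36 ug/mL
compound 2 `COc1ccc(S(=O)(=O)Nc2cccc3c(C#N)c[nH]c23)cc1`: 1.4 ug/mL
compound 3 `COc1ccc(S(=O)(=O)Nc2cccc3c(Cl)c[nH]c23)cc1`: 0.55 ug/mL

Compound 3 has the lowest number of the three, and so is the strongest inhibitor measured so far. Compound 2 lies closest at 1.4 ug/mL, while compound 1 lies furthest at 36 ug/mL. The next compound is compound 4 `Nc1ccc(S(=O)(=O)Nc2cccc3c(Cl)c[nH]c23)cc1`, which has amino in place of methoxy on an aromatic carbon.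

Going by the values given here, no measured step isolates this exchange. The only one available, a 2.5-fold lower number from compound 2 to compound 3 (0.41 log units; beyond the scatter), is modest and concerns the chloro and cyano exchange, not the group that changes here. Compound 1 carries the amino group but has no chloro, and its 36 ug/mL combines two differences from compound 3, so it cannot be assigned to the amino group alone. It does hint at a higher number, though probably only a modest rise in this assay with the chloro retained.

The estimated step is a 2.7-fold higher number from compound 3 to compound 4 (0.44 log units; beyond the scatter). For compound 4 the expected value is 1.5 ug/mL, with an estimated range of 0.4 ug/mL to 6 ug/mL.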

Compound 4, half-maximal inhibitory concentration: 10 ug/mL
Compound 4: middle estimate off by 6.7-fold (0.82 log units), on the low side; the measured number lies above the stated range.
By their numbers in this assay, from the lowest: compound 3; then compound 2; then compound 4; then compound 1.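

In this assay, with the chloro held fixed, the exchange of methoxy for amino para to a large group gives a large step (an 18-fold higher number from compound 3 to compound 4 (1.26 log units; beyond the scatter)), so this position strongly affects the number. With the amino held fixed, chloro in place of hydrogen gives a step printed only as modest (a 3.6-fold lower number from compound 1 to compound 4 (0.56 log units; beyond the scatter)), so in these pairs the exchange at the para position counts for more than the chloro exchange. Nothing measured here accounts for the size of either step.

As far as these compounds go, it remains open how a hydroxyl, an ethoxy or a dimethylamino group would read at this position, and so whether methoxy is special or amino is simply poor there. Also open, from the compounds shown here alone, is whether the chloro step holds at the same size with methoxy in place of amino.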